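The source may report more compounds than this note shows. Statements on the series, on what has been measured and on what is new or still open speak of the compounds shown alone.

In a functional assay on HCT-116 cells (Homo sapiens) for cytotoxicity, read by MTT assay (on this read-out lower numbers stand for stronger inhibition and higher numbers for weaker inhibition), three compounds already carry a result. Compound 1 `CCOC(=O)Nc1ccc(S(=O)(=O)N2C(=O)N[C@@H](c3ccccc3)C2C)cc1Cl` gives 5500 nM in this assay, and compound 3 `CCOC(=O)Nc1ccc(S(=O)(=O)N2C[C@H](c3ccccc3)NC2=O)cc1CC` gives 70 nM in this assay. Compound 2 `Cc1cc(S(=O)(=O)N2C(=O)N[C@@H](c3ccccc3)C2C)ccc1NC(=O)c1ccc([N+](=O)[O-])cc1` is different: its result is only > 10000 nM, which is a limit of this assay and not a number, one of the values sitting at the limit of > 10000 nM in this assay, at which 1 of the 3 values shown sits. Compound 4 `Cc1cc(S(=O)(=O)N2C(=O)N[C@@H](c3ccccc3)C2C)ccc1NC(=O)c1ccc(N)cc1` differs from compound 2 in a single place: amino in place of nitro on an aromatic carbon. Among the measured compounds shown here, no measured pair shows this same change, so its size is open. The step expected is a step that the limit leaves unreadable from compound 2 to compound 4, and it is expected to stay within the usual scatter. Compound 4 is therefore estimated at about 15000 nM, within a range from 3000 nM to 60000 nM.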

Compound 4, half-maximal inhibitory concentration: > 10000 nM
Compound 4 ended at the assay's limit (the forecaster's own chance of this, stated with the estimate: 55%); the middle value does not contradict the limit.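

Compound 2 and compound 4 both stop at a limit rather than a number in this assay, so no step can be read between them: the limit of > 10000 nM in this assay, at which 2 of the 4 values shown sit.

The compounds shown leave open how much amino in place of nitro changes the result.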